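Moving Fluorine on the Benzyl Amide

This account rests on a few compounds, and the source may have more. Where it says the series, first, only, none or still open, it means among the compounds named here.

Compound 1 `O=C(/C=C/c1coc2cc(O)ccc2c1=O)NCc1ccccc1`: 4690 nM
Compound 2 `COc1ccc2c(=O)c(/C=C/C(=O)NCc3cccc(F)c3)coc2c1`: 10100 nM
Compound 3 `Cc1ccccc1NC(=O)/C=C/c1coc2cc(O)ccc2c1=O`: 11100 nM

All three were tested in a functional assay on Huh-7 cells (Homo sapiens) for inhibition, read by MTT assay, with a stated time of 48 h; on this read-out higher numbers stand for weaker inhibition and lower numbers for stronger inhibition. Compound 2 gives the second highest of the three numbers: its value sits within the usual scatter of the value of compound 3, while the value of compound 1 lies further away, beyond the scatter. Going by the values given here, the one single-change step among the measured compounds is a 2.4-fold higher number from compound 1 to compound 3 (0.37 log units; beyond the scatter), a modest weakening.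

Compound 4 `COc1ccc2c(=O)c(/C=C/C(=O)NCc3ccc(F)cc3F)coc2c1` differs from compound 2 in one place: 2,4-difluorophenyl in place of 3-fluorophenyl on a saturated chain carbon bound to an amide-type nitrogen. Among the compounds with values here, the only measured step concerns an exchange of benzyl for 2-methylphenyl and says nothing about adding or moving fluorine on the benzyl ring; no measured pair isolates such a fluorine change. With nothing pointing in either direction, the step is expected to stay within the scatter, a 1.0-fold lower number from compound 2 to compound 4 (0.00 log units; within the scatter). Compound 4 is therefore expected to give about 10000 nM in this assay, with a range from 4000 nM to 25000 nM.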

Compound 4, half-maximal inhibitory concentration: > 100000 nM
Compound 4: only a limit was reported; the forecaster's own chance of this, stated with the estimate: 10%; middle value at least 10-fold (1.00 log units) away from the limit.
By their numbers in this assay, from the lowest: compound 1; then compounds 2 and 3 (each within the scatter of the next). At a limit, above all of these: compound 4.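

In this assay, the fluorine pattern on this benzyl ring turns out to matter a great deal: 2,4-difluorophenyl in place of 3-fluorophenyl gives an at least 9.9-fold higher number from compound 2 to compound 4 (0.99 log units; beyond the scatter). Going by these compounds alone, the only earlier step, a 2.4-fold higher number from compound 1 to compound 3 (0.37 log units; beyond the scatter), was modest and involved a different exchange, so it gave no sign that one extra fluorine at this place, on a saturated chain carbon bound to an amide-type nitrogen, could shift the number so far. The result for compound 4 is a limit and not an exact number: the limit of > 100000 nM in this assay, at which 1 of the 4 values shown sits.

Going by these compounds, it remains open whether the added fluorine, the changed fluorine pattern or both account for this step. Also open, on these data alone, is how a chlorine or a methoxy group on this ring, or an amine in its place, would read in this assay.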